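Acid dissociation in the diamine series: compound 4

The source may report more compounds than this note shows. Statements on the series, on what has been measured and on what is new or still open speak of the compounds shown alone.

Measured so far:
Compound 1 `COc1ccc(F)cc1CNCCCNc1ccnc2cc(Cc3ccc(C#N)cc3)ccc12` gives 9.47 in a physicochemical assay for acid dissociation.
Compound 2 `Fc1ccc(-c2ccc3c(NCCCNCc4ccco4)ccnc3c2)cc1` gives 9.47.
Compound 3 `COc1cccc(CNCCCNc2ccnc3cc(-c4ccc(F)cc4)ccc23)c1O` gives 9.47.

Compound 2 stands level with compounds 1 and 3 at the digits shown in this assay; its nearest neighbour is compound 1 and its furthest is compound 3, and in neither case is there a change beyond the scatter. Among the measured compounds shown here, the only single-site step measured so far, no change at the digits printed from compound 2 to compound 3 (within the scatter), put a 2-hydroxy-3-methoxyphenyl in place of a furan-2-yl on a saturated chain carbon bound to an amine nitrogen and left the read-out unchanged.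

Compound 4 `COc1cccc(Oc2ccc3c(NCCCNCc4ccco4)ccnc3c2)c1` has not yet been measured. It differs from compound 2 as follows: 3-methoxyphenoxy in place of 4-fluorophenyl on an aromatic carbon. For the measured compounds named here, this change sits on an aromatic carbon of the fused two-ring system, meta and para to a fused ring, a place at which no measured step exists; the shared chain carrying the two amine nitrogens is untouched. Going by the values given here, with the one measured step flat and the three measured values level, the expected step of no change at the digits printed from compound 2 to compound 4 (within the scatter) is none beyond the scatter. Compound 4 is therefore estimated at 9.47, with a range from 9.15 to 9.8.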

Compound 4, acid dissociation constant: 9.28
Beside the measured number, compound 4's estimate is 0.19 log units above it; low and high end bracket the measured number.
By their numbers in this assay, from the lowest: compounds 4, 1, 2 and 3 (each within the scatter of the next).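

In this assay, among the compounds shown here, the step at this aromatic carbon of the shared core, meta and para to a fused ring, reads (a number 0.19 log units lower from compound 2 to compound 4 (within the scatter)), giving the first measured exchange at this position. It also extends the flat picture beyond the saturated chain carbon bound to an amine nitrogen, the only site with a single-place step until now, so at two separate sites one exchange each has left the read-out within the scatter. The exchange is not a trivial one by count: 3-methoxyphenoxy brings 9 heavy atoms and 2 hydrogen-bond acceptors where 4-fluorophenyl has 7 heavy atoms and 0 hydrogen-bond acceptors, yet no measured supporting data tie this reading to any feature of either group.

On these data alone, whether an amine or a carboxylic acid on this aromatic carbon would also stay within the scatter remains open, since both groups compared here carry a six-membered aromatic ring of carbon only. Also open, as far as these compounds go, is how the read-out would respond to a longer chain in place of the one carrying the two amine nitrogens, the part shared by compounds 2 and 4.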